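A few compounds are considered here, and "the series" means these few. Any claim that something is new, unique, unknown or untested is made for them only; others in the source may bear on it.

Measured so far:
- compound 1, `COc1cc(Oc2cccc(Nc3ccccc3)c2)cc(OC)c1CNCc1ccc(Cl)cc1`: in a functional assay on HCT-15 cells (Homo sapiens) for inhibition, read by MTT assay, with a stated time of 72 h (a higher number here means a weaker inhibitor, a lower number a stronger inhibitor), compound 1 gives 4850 nM.
- compound 2, `COc1cc(Oc2cccc(Nc3ccccc3)c2)cc(OC)c1CNC(C)C`: for compound 2 this assay reports only a limit, > 20000 nM.
- compound 3, `COc1cc(Oc2cccc(Nc3ccccc3)c2)cc(OC)c1CN[C@H](C)c1ccccc1`: in this assay compound 3 gives 7550 nM.

Among the two numbers shown, compound 1 has the lowest, though compound 3 sits within the scatter of it, as a 1.6-fold higher number from compound 1 to compound 3 (0.19 log units; within the scatter) shows. Within the data shown here, the only step beyond the scatter is an at least 4.1-fold higher number from compound 1 to compound 2 (0.61 log units; beyond the scatter), where the aromatic ring on the amine nitrogen is lost altogether; the single limit here is the limit of > 20000 nM in this assay, at which 1 of the 3 values shown sits.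

Compound 4, `COc1cc(Oc2cccc(Nc3ccccc3)c2)cc(OC)c1CNCc1ccc(O)cc1`, keeps that ring and changes only one atom on it: hydroxy in place of chloro on an aromatic carbon. Among the measured compounds shown here, no measured step swaps one substituent for another on this ring, so the evidence is indirect. Keeping the ring intact mattered in an at least 4.1-fold higher number from compound 1 to compound 2 (0.61 log units; beyond the scatter), while a different arrangement of the same ring in a 1.6-fold higher number from compound 1 to compound 3 (0.19 log units; within the scatter) changed little. Compound 4 is therefore expected to stay close to compound 1, with a step of a 1.4-fold higher number from compound 1 to compound 4 (0.16 log units; within the scatter). The estimate for compound 4 in this assay is 7000 nM, between 2500 nM and 20000 nM.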

Compound 4, half-maximal inhibitory concentration: 3430 nM
The estimate for compound 4 lay 2.0-fold (0.31 log units) above the measured number; the measured number falls inside the stated range.
By their numbers in this assay, from the lowest: compounds 4, 1 and 3 (each within the scatter of the next, the first and the last beyond it). At a limit, above all of these: compound 2.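

Among these compounds, on the aromatic ring, para to a large group, hydroxy can stand in place of chloro without a change beyond the scatter in this assay, with a 1.4-fold lower number from compound 1 to compound 4 (0.15 log units; within the scatter), so at this position a group with a hydrogen-bond donor and a group with none give matching results, a swap that no earlier pair of compounds tested. The 4-hydroxybenzyl group also stands apart from the other two amine substituents, with a 2.2-fold lower number from compound 3 to compound 4 (0.34 log units; beyond the scatter) and an at least 5.8-fold lower number from compound 2 to compound 4 (0.76 log units; beyond the scatter), so the second step is a minimum and not an exact size. Compound 2 gives only a limit of the assay, not a number: the limit of > 20000 nM in this assay, at which 1 of the 4 values shown sits.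

Going by these compounds, what an amine, a carboxylic acid or a plain hydrogen would give at this position remains open. On these data alone, whether the hydrogen of the hydroxy group plays any part also remains open, and a methoxy group here would bear on that.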